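Compound 3: a methyl added to the benzamide of compound 2

The compounds below may be only part of what the source reports. "The series", "measured", "known", "first", "only" and "open" are said of these compounds alone.

The series shares one core. Compound 1 `N#CC1=C(N)N(c2ccc(S(N)(=O)=O)cc2)C2=C(C(=O)CCC2)C1c1ccc(Cl)cc1Cl` carries a free amine, and compound 2 `N#CC1=C(NC(=O)c2ccccc2)N(c2ccc(S(N)(=O)=O)cc2)C2=C(C(=O)CCC2)C1c1ccc(Cl)cc1Cl` carries a benzoyl group on that nitrogen. In a functional assay on Ehrlich cells (Mus musculus) for cytotoxicity, read by trypan blue exclusion, with a stated time of 2 h, tested at 50 ug/mL (on this read-out higher numbers stand for a stronger effect at the one concentration tested and lower numbers for a weaker effect), compound 1 gives 65% and compound 2 gives 70%. Compound 2 thus holds the largest number shown, yet the step of a number 5 percentage points higher from compound 1 to compound 2 (within the scatter) is within the scatter, so no order between the two compounds is claimed. Compound 3 `Cc1ccc(C(=O)NC2=C(C#N)C(c3ccc(Cl)cc3Cl)C3=C(CCCC3=O)N2c2ccc(S(N)(=O)=O)cc2)cc1` differs from compound 2 by methyl in place of hydrogen on an aromatic carbon. Going by the values given here, no measured step touches the benzoyl ring itself; the only step available, a number 5 percentage points higher from compound 1 to compound 2 (within the scatter), concerns the amine nitrogen and is within the scatter. With one carbon entering on the ring, compound 3 is expected to give about 70% (from 55% to 85%). The expected step of no change at the digits printed from compound 2 to compound 3 (within the scatter) is therefore estimated to stay within the scatter, in no clear direction.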

Compound 3, a percentage reported as activity, at one concentration (the size of the read-out at that concentration, not a potency): 40%
Compound 3: the middle estimate sits 30 percentage points above what was measured, outside the stated range (below it).
By their numbers in this assay, from the lowest: compound 3; then compounds 1 and 2 (each within the scatter of the next).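

Going by these compounds alone, a single methyl on the benzoyl ring, para to a large group, gives a number 30 percentage points lower from compound 2 to compound 3 (beyond the scatter) in this assay, the first step that lies beyond the scatter. Acylation of the amine nitrogen therefore cannot be read as one effect: benzoyl stays within the scatter of the free amine, whereas (4-methylphenyl)carbonyl gives a number 25 percentage points lower from compound 1 to compound 3 (beyond the scatter) on the same read-out. Within the data shown here, the ring that no earlier step touched is thus a place where a small change moves the number. Nothing available bears on the reason for this drop.

Going by these compounds, whether the drop is specific to methyl stays open, since a methoxy, a chlorine or a carboxylic acid at this place would show if other groups behave alike. On these data alone, with one concentration per compound, it also stays open whether the step would hold at other concentrations.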